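Chloro on the Phenyl of a Brominated Triazole Scaffold

The source may hold more compounds than are shown below. What is called first, only, known or untested is meant among the compounds shown, and "the series" means these compounds.

Measured compounds in a functional assay on SW480 cells (Homo sapiens) for cytotoxicity, read by MTT assay, with a stated time of 4 days; a lower number here means a stronger inhibitor, a higher number a weaker inhibitor:
- Compound 1 `C=C1C[C@]23C[C@@]1(O)CC[C@H]2c1ccc(O)c(C)c1[C@@H]3Cn1cc(-c2ccccc2)nn1` gives > 20000 nM, which is a limit of the assay and not a number.
- Compound 2 `C=C1C[C@]23C[C@@]1(O)CC[C@H]2c1cc(Br)c(O)c(C)c1[C@@H]3Cn1cc(-c2ccccc2)nn1` gives > 20000 nM, again a limit rather than a number.
- Compound 3 `Cc1ccc(-c2cn(C[C@H]3c4c(ccc(O)c4C)[C@@H]4CC[C@@]5(C)C[C@]43CC5=O)nn2)cc1` gives > 20000 nM, also a limit.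

Compound 2 therefore stands nowhere in particular on the numbers shown: all that is known is that it did not reach half-maximal inhibition within the tested range, and the same holds for the two compounds beside it. Among the measured compounds shown here, the one single-change step among the measured compounds, a step that the two limits leave unreadable from compound 1 to compound 2, cannot be sized, because both ends sit at a limit (the limit of > 20000 nM in this assay, at which 3 of the 3 values shown sit).

Compound 4 `C=C1C[C@]23C[C@@]1(O)CC[C@H]2c1cc(Br)c(O)c(C)c1[C@@H]3Cn1cc(-c2ccc(Cl)cc2)nn1` differs from compound 2 by a single change: chloro in place of hydrogen on an aromatic carbon. No measured step speaks to this change, since the only step available is unreadable and the three shown values are all limits. What the data do offer is that every compound of this shared core has so far stayed weak in this assay.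

Compound 4 is therefore expected to behave like compound 2, with a step that the limit leaves unreadable from compound 2 to compound 4 in this assay, most likely remaining at the limit. The estimate for compound 4 is 30000 nM, within a range of 12000 nM to 100000 nM.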

Compound 4, half-maximal inhibitory concentration: 18000 nM
Beside the measured number, compound 4's estimate is 1.7-fold (0.22 log units) above it; measured number inside the range.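

Chloro on an aromatic carbon of the six-membered aromatic ring of carbon only, para to a large group, turns phenyl into 4-chlorophenyl, and compound 4 gives the first value in this assay that is a number and not a limit. The step reads an at least 1.1-fold lower number from compound 2 to compound 4 (0.04 log units; that floor lies within the scatter), so only its floor is fixed: the true size could be small or much larger, and the change cannot yet be called a real gain. Compound 4 is still a weak inhibitor in this assay, and the other values shown are limits: the limit of > 20000 nM in this assay, at which 3 of the 4 values shown sit.

As far as these compounds go, it remains open whether this result belongs to chloro itself or whether other groups at the same place, such as fluoro, methoxy or an amine, would give a similar number. Also open, from the compounds shown here alone, is whether a carboxylic acid or a longer chain at this place would shift the value far enough to be read clearly beyond the usual scatter of this assay, and whether chloro would do the same on a ring without the bromo.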